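The source may hold more compounds than are shown below. What is called first, only, known or untested is meant among the compounds shown, and "the series" means these compounds.

Going by the values given here, compound 1 `O=C(COc1ccc(C(=O)/C=C/c2ccc(F)c(F)c2)cc1)N[C@H]1CCOC1=O` is the only member of this small set with a numerical result: in a functional assay on DU-145 cells (Homo sapiens) for antiproliferative activity, read by MTT assay, with a stated time of 72 h (on this read-out higher numbers stand for weaker inhibition and lower numbers for stronger inhibition), compound 1 gives 19800 nM. Compound 2 `O=C1OCC[C@@H]1NC(=S)SCCOc1cccc2ccccc12` reaches only a limit of the assay, recorded as > 64000 nM. Compound 3 `O=C(CNc1cccc(Cl)c1)N[C@H]1CCOC1=O` likewise stops at a limit, > 64000 nM. Among the compounds with values here, two of the three results thus sit at the limit of > 64000 nM in this assay, at which 2 of the 3 values shown sit, so compound 1 stands alone as the one measured number.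

Compound 4 `O=C(COc1ccc(C(=O)/C=C/c2cccc([N+](=O)[O-])c2)cc1)N[C@H]1CCOC1=O` has not yet been tested. It differs from compound 1 by 3-nitrophenyl in place of 3,4-difluorophenyl on a double-bonded chain carbon bound to a double-bonded chain carbon. Within the data shown here, no measured pair in this set shows the effect of such an exchange, so the size of the step is open; the expectation is for a change that stays within the usual scatter of this assay, in no preferred direction. Compound 4 is expected to give about 16000 nM, within a range from 5000 nM to 50000 nM. The estimated step is a 1.2-fold lower number from compound 1 to compound 4 (0.09 log units; within the scatter).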

Compound 4, half-maximal inhibitory concentration: 41800 nM
Compound 4: middle estimate off by 2.6-fold (0.42 log units), on the low side; low and high end bracket the measured number.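

In this assay, going by these compounds alone, replacing 3,4-difluorophenyl with 3-nitrophenyl on a double-bonded chain carbon bound to a double-bonded chain carbon gives the first step in this set that can be read: a 2.1-fold higher number from compound 1 to compound 4 (0.32 log units; beyond the scatter). The step is modest, but it shows that the result at this position depends on the group placed there, even though both groups carry one six-membered aromatic ring of carbon only. Compound 4 still gives a number, so this exchange does not take it to the limit of the assay: the limit of > 64000 nM in this assay, at which 2 of the 4 values shown sit.

A single exchange cannot separate the departure of the fluorines from the arrival of the nitro group. The compounds shown also leave open how a plain phenyl, a 3-aminophenyl or a phenyl carrying a carboxylic acid would read at this place.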